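This account rests on a few compounds, and the source may have more. Where it says the series, first, only, none or still open, it means among the compounds named here.

Compound 1 `Nc1ccc(-c2cc(=O)c3c(N)c(F)c(Br)c(F)c3o2)cc1F` — in a functional assay on HeLa cells (Homo sapiens) for cytotoxicity, read by neutral red uptake, with a stated time of 3 days (a lower number here means a stronger inhibitor, a higher number a weaker inhibitor), compound 1 gives > 100000 nM, which is a limit of the assay and not a number.
Compound 2 `COc1c(F)c(N)c2c(=O)cc(-c3ccc(N)c(F)c3)oc2c1F` — in this assay compound 2 gives 34000 nM.
Compound 3 `Nc1ccc(-c2cc(=O)c3c(N)c(F)c(CO)c(F)c3o2)cc1F` — in this assay compound 3 gives 24000 nM.

Of the two numbers shown, compound 3 sits beside compound 2: the difference a 1.4-fold lower number from compound 2 to compound 3 (0.15 log units; within the scatter) is within the scatter, so the two cannot be told apart. Compound 1 gives only a limit, at the limit of > 100000 nM in this assay, at which 1 of the 3 values shown sits.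

Compound 4 `[N-]=[N+]=Nc1c(F)c(N)c2c(=O)cc(-c3ccc(N)c(F)c3)oc2c1F` is not yet measured. It differs from compound 3 in one place: azido in place of hydroxymethyl on an aromatic carbon. For the measured compounds named here, two measured steps touch the same position. Going from bromo to hydroxymethyl gave an at least 4.1-fold lower number from compound 1 to compound 3 (0.61 log units; beyond the scatter), and from bromo to methoxy an at least 2.9-fold lower number from compound 1 to compound 2 (0.46 log units; beyond the scatter), both at least modest. Exchanging methoxy for hydroxymethyl gave a 1.4-fold lower number from compound 2 to compound 3 (0.15 log units; within the scatter), within the scatter. Azido is a group for which no step is shown; the only guide is that two different small groups at this position gave numbers that could not be told apart. The expected change is therefore small, a 1.3-fold higher number from compound 3 to compound 4 (0.10 log units; within the scatter), with no direction claimed beyond the scatter. Compound 4 is estimated at 30000 nM, within a range from 8000 nM to 100000 nM.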

Compound 4, half-maximal inhibitory concentration: 1200 nM
For compound 4 the middle estimate is 25-fold (1.40 log units) above the measured one; measured number outside the range, below it.
By their numbers in this assay, from the lowest: compound 4; then compounds 3 and 2 (each within the scatter of the next). At a limit, above all of these: compound 1.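

At the aromatic carbon ortho to two fluoro groups, hydroxymethyl and methoxy gave numbers that could not be told apart, which made the position look tolerant of change, but azido shows that it is not: in this assay the exchange gives a 20-fold lower number from compound 3 to compound 4 (1.30 log units; beyond the scatter) and, starting from methoxy, a 28-fold lower number from compound 2 to compound 4 (1.45 log units; beyond the scatter). Starting from bromo, the exchange gives an at least 83-fold lower number from compound 1 to compound 4 (1.92 log units; beyond the scatter). That step is open-ended, as compound 1 gives a limit of the assay and not a number: the limit of > 100000 nM in this assay, at which 1 of the 4 values shown sits.

The compounds shown leave open whether this large step belongs to azido alone or would also appear with another nitrogen-containing group on the same carbon, such as an amine or a nitrile. They also cannot say why azido stands apart from hydroxymethyl, methoxy and bromo, and with only HeLa cells in this assay, they cannot show whether the lower number of compound 4 would hold in any other cell type.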